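Swapping an Aromatic Ester for a Hydroxy-Bearing One

The source may hold more compounds than are shown below. What is called first, only, known or untested is meant among the compounds shown, and "the series" means these compounds.

Compounds measured so far:
- Compound 1 `Cc1ccc(C(=O)OC2(C(=O)Nc3ccc([N+](=O)[O-])cc3)CCCCC2)cc1`: 45.4 nM
- Compound 2 `O=C(OC1(C(=O)Nc2ccc([N+](=O)[O-])cc2)CCCCC1)c1ccc(Cl)cc1`: 10.3 nM
- Compound 3 `O=C(/C=C/c1ccccc1)OC1(C(=O)Nc2ccc([N+](=O)[O-])cc2)CCCCC1`: 50.5 nM

The three compounds share one core and differ only in the acid part of the ester. In a functional assay on NFS-60 cells (Mus musculus) for inhibition, read by MTT assay, with a stated time of 72 h (on this read-out lower numbers stand for stronger inhibition and higher numbers for weaker inhibition), compound 1 gives 45.4 nM, which is the second highest of the three numbers; its nearest neighbour is compound 3, and compound 2 lies furthest from it. The step of a 1.1-fold higher number from compound 1 to compound 3 (0.05 log units; within the scatter) stays within the scatter, whereas the step of a 4.4-fold lower number from compound 1 to compound 2 (0.64 log units; beyond the scatter) is a modest gain. Compound 4 `O=C(OC1(C(=O)Nc2ccc([N+](=O)[O-])cc2)CCCCC1)C(O)c1ccccc1` is not yet measured. Compared with compound 1 it carries hydroxy(phenyl)methyl in place of 4-methylphenyl on a carbonyl carbon.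

For the measured compounds named here, none of the measured steps tries this kind of exchange: a hydrogen-bond donor enters where the measured compounds offer none. Going by the values given here, the closest precedent is the step from compound 1 to compound 3, where a different group on the carbonyl carbon left the number essentially unchanged; the step to compound 2 shows the number can move modestly either way. A step of about a 1.5-fold higher number from compound 1 to compound 4 (0.19 log units; within the scatter) is therefore expected in this assay, most likely no change beyond the scatter, with a wide range. Compound 4 is estimated at 70 nM, between 20 nM and 250 nM.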

Compound 4, half-maximal inhibitory concentration: 7.8 nM
Estimate against measurement, compound 4: 9.0-fold (0.95 log units) above, and the stated range ends above it.
By their numbers in this assay, from the lowest: compounds 4 and 2 (each within the scatter of the next); then compounds 1 and 3 (each within the scatter of the next).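

In this assay, the group on the carbonyl carbon need not be a plain aromatic ring or a 2-phenylethenyl chain to give a low number: hydroxy(phenyl)methyl brings a 5.8-fold lower number from compound 1 to compound 4 (0.76 log units; beyond the scatter) and also a 6.5-fold lower number from compound 3 to compound 4 (0.81 log units; beyond the scatter) (both modest steps). Before this result, only the 4-chlorophenyl group of compound 2 stood apart from the other two esters, yet a group with a hydrogen-bond donor now sits level with it, as a 1.3-fold lower number from compound 2 to compound 4 (0.12 log units; within the scatter) shows, so two quite different groups give numbers that cannot be told apart here. What lies behind these steps cannot be said, as nothing measured alongside this assay bears on the result.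

The compounds shown leave open whether the hydroxy group itself matters, as the change from 4-methylphenyl also removes the methyl group and puts a carbon between the carbonyl and the ring. A plain benzyl group, with no hydroxy, or an amine where the hydroxy now stands would be the obvious neighbours for pulling these parts of the change apart.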